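The source may report more compounds than this note shows. Statements on the series, on what has been measured and on what is new or still open speak of the compounds shown alone.

Compound 1 `CN(C(=O)NC(=O)c1ccccc1F)c1nc(C(F)(F)F)c(C(=O)N/N=C/c2ccc(C(F)(F)F)cc2)s1` gives 4.56 ug/mL in a functional assay on HepG2 cells (Homo sapiens) for inhibition, read by MTT assay, with a stated time of 72 h; on this read-out higher numbers stand for weaker inhibition and lower numbers for stronger inhibition. Compound 2 `CN(C(=O)NC(=O)c1ccccc1F)c1nc(C(F)(F)F)c(C(=O)N/N=C/c2ccccc2C(F)(F)F)s1` gives 5.39 ug/mL in this assay. Compound 3 `CNc1nc(C)c(C(=O)N/N=C/c2ccccc2C(F)(F)F)s1` reaches only a limit of this assay, > 100 ug/mL.

Among the two numbers, compound 1 has the lower one, though the step of a 1.2-fold higher number from compound 1 to compound 2 (0.07 log units; within the scatter) is within the scatter, so the two cannot be ranked. Compound 4 `CN(C(=O)NC(=O)c1c(F)cccc1F)c1nc(C(F)(F)F)c(C(=O)N/N=C/c2ccc(C(F)(F)F)cc2)s1` differs from compound 1 by fluoro in place of hydrogen on an aromatic carbon. For the measured compounds named here, no measured step touches this ring: the only step recorded, from compound 1 to compound 2, moves the trifluoromethyl on a different ring and stays within the scatter. For compound 4 the expected step is therefore a 1.0-fold lower number from compound 1 to compound 4 (0.01 log units; within the scatter), with no change beyond the scatter. Compound 4 is estimated at 4.5 ug/mL in this assay, likely between 2 ug/mL and 10 ug/mL.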

Compound 4, half-maximal inhibitory concentration: 49.6 ug/mL
For compound 4 the middle estimate is 11-fold (1.04 log units) below the measured one; the measured number lies above the stated range.
By their numbers in this assay, from the lowest: compounds 1 and 2 (each within the scatter of the next); then compound 4. At a limit, above all of these: compound 3.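

Adding one fluoro, which turns the (2-fluorophenyl)carbonyl group into the (2,6-difluorophenyl)carbonyl group, weakens inhibition in this assay, with an 11-fold higher number from compound 1 to compound 4 (1.04 log units; beyond the scatter). The earlier step moved a trifluoromethyl on the other ring and stayed within the scatter, so this ring is the first place shown where a single small change clearly counts. Nothing given here explains why this happens.

As far as these compounds go, it remains open how a chloro, a methoxy or an amine would behave in place of this hydrogen, and whether the same fluoro has a similar effect in compound 2.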